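Hydrazone replacement on a chloropyrimidine core, HT-29 growth inhibition

This account rests on a few compounds, and the source may have more. Where it says the series, first, only, none or still open, it means among the compounds named here.

Compound 1 `C=CC(=O)Nc1cccc(Nc2nc(N/N=C/c3ccc(F)cc3)ncc2Cl)c1`: 6340 nM
Compound 2 `CN(C)C/C=C/C(=O)Nc1cccc(Nc2nc(N/N=C/c3ccncc3)ncc2Cl)c1`: 25200 nM

Two measured compounds share a core and differ in two places, so their values can only be set side by side. In an ADME assay on HT-29 cells (Homo sapiens) for inhibition, read by MTT assay, with a stated time of 72 h (a lower number here means a stronger inhibitor, a higher number a weaker inhibitor), compound 1 gives 6340 nM, and in this assay compound 2 gives 25200 nM, the higher of the two numbers, with the gap to compound 1 lying beyond the scatter of repeated measurements.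

Compound 3 `COc1cccc(/C(C)=N/Nc2ncc(Cl)c(Nc3cccc(NC(=O)/C=C/CN(C)C)c3)n2)c1` has not been measured in this assay. It differs from compound 2 in one place: a group of 11 heavy atoms (9 carbon, 1 nitrogen, 1 oxygen; one six-membered aromatic ring of carbon only) in place of a group of 8 heavy atoms (6 carbon, 2 nitrogen; one six-membered aromatic ring with 1 hetero atom), on a nitrogen on an aromatic ring. The acrylamide side of the molecule is unchanged, so the two compounds are directly comparable at that site alone.

Among the compounds with values here, no single-change step between measured compounds is available. The size of the effect can only be estimated. A moderate move toward a lower number is expected for compound 3, on the order of a 2.1-fold lower number from compound 2 to compound 3 (0.32 log units; beyond the scatter), though a change that stays within the scatter is also plausible. In this assay compound 3 is therefore estimated at 12000 nM, within a range from 4000 nM to 40000 nM.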

Compound 3, half-maximal inhibitory concentration: 3870 nM
Compound 3: the middle estimate sits 3.1-fold (0.49 log units) above what was measured; measured number below the stated range.
By their numbers in this assay, from the lowest: compounds 3 and 1 (each within the scatter of the next); then compound 2.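

In this assay, replacing the group of 8 heavy atoms, with its six-membered aromatic ring with 1 hetero atom, by the group of 11 heavy atoms, with its six-membered aromatic ring of carbon only, gives a 6.5-fold lower number from compound 2 to compound 3 (0.81 log units; beyond the scatter) on a nitrogen on an aromatic ring, while the acrylamide side stays the same. This single-place comparison shows that a change at this position alone can move the number beyond the scatter, something the two earlier compounds, which differ in two places, could not show. Nothing measured here explains the shift, which stands only as an observed difference between this one pair of compounds.

The step changes the ring, the atom count and the oxygen together, so the compounds shown leave open which of these parts goes with the lower number. They also leave open how the number would respond if the group of 11 heavy atoms carried a trifluoromethyl group or a nitrile, or if a saturated piperidine ring took the place of its aromatic ring.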